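The compounds below may be only part of what the source reports. "The series", "measured", "known", "first", "only" and "open" are said of these compounds alone.

Values in a functional assay (blood) for inhibition, with Homo sapiens as the target; on this read-out higher numbers stand for weaker inhibition and lower numbers for stronger inhibition:

- Compound 1 `CC(C)(C)Sc1c(CC(C)(C)C(=O)O)n(Cc2ccc(Cl)cc2)c2ccc(CCc3ccc4ccccc4n3)cc12`: > 3000 nM
- Compound 2 `CC(C)(C)Sc1c(CC(C)(C)C(=O)O)n(Cc2ccc(Cl)cc2)c2ccc(OCc3ccc4cc(F)c(F)cc4n3)cc12`: > 3000 nM
- Compound 3 `CC(C)(C)Sc1c(CC(C)(C)C(=O)O)n(Cc2ccc(Cl)cc2)c2ccc(OCc3cc4ccccc4cn3)cc12`: > 3000 nM

Compound 3 gives only a limit, > 3000 nM, and not a number. It shares this position with the other two compounds, as all sit at the limit of > 3000 nM in this assay, at which 3 of the 3 values shown sit.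

Compound 4 `CC(C)(C)Sc1c(CC(C)(C)C(=O)O)n(Cc2ccc(Cl)cc2)c2ccc(OCc3nc4ccccc4s3)cc12` carries 1,3-benzothiazol-2-yl in place of isoquinolin-3-yl on a saturated chain carbon bound to an oxygen on an aromatic ring.

The closest evidence is a step that the two limits leave unreadable from compound 2 to compound 3, a change at the same place. The other is a step that the two limits leave unreadable from compound 1 to compound 3. Neither offers a size to carry over, so no step beyond the scatter is expected in this assay, in either direction. The expected change is a number no higher from compound 3 to compound 4 (the limit leaves the size open). For compound 4 the estimated value is 3000 nM, within an expected range of 1000 nM to 9000 nM.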

Compound 4, half-maximal inhibitory concentration: 260 nM
Estimate against measurement, compound 4: 12-fold (1.06 log units) above, outside the stated range (below it).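

In this assay, the group on the saturated chain carbon bound to an oxygen on an aromatic ring can clearly change the result: 1,3-benzothiazol-2-yl in place of isoquinolin-3-yl gives an at least 11-fold lower number from compound 3 to compound 4 (1.06 log units; beyond the scatter). The replacement of the difluorinated group gives an at least 11-fold lower number from compound 2 to compound 4 (1.06 log units; beyond the scatter), and (1,3-benzothiazol-2-yl)methoxy in place of 2-(quinolin-2-yl)ethyl gives an at least 11-fold lower number from compound 1 to compound 4 (1.06 log units; beyond the scatter). Compound 4 is the only one shown with a measured number rather than a limit: the limit of > 3000 nM in this assay, at which 3 of the 4 values shown sit.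

From the compounds shown here alone, whether the sulfur or the five-membered ring matters more stays open. A 1,3-benzoxazol-2-yl group, with oxygen in place of sulfur, would help separate the two.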